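Swapping an Amino for a Hydroxy on a Nucleoside Base

This account rests on a few compounds, and the source may have more. Where it says the series, first, only, none or still open, it means among the compounds named here.

Compound 1 `C=C1[C@@H](O)[C@H](n2cnc3c(N)ncnc32)O[C@@H]1CO` and compound 3 `C=C1[C@H](n2cnc3c(N)nc(N)nc32)O[C@H](CO)[C@H]1O` carry the same sugar but different bases; the difference between the two cores is not broken down here. In a functional assay on L1210 cells (Mus musculus) for inhibition (on this read-out higher numbers stand for weaker inhibition and lower numbers for stronger inhibition), compound 1 gives 228000 nM. Compound 3 gives 8200 nM, and the gap between compound 1 and compound 3 lies beyond the usual scatter of repeated measurements, so compound 3 is the stronger of the two. Compound 2 `C=C1[C@@H](O)[C@H](n2cnc3c(O)ncnc32)O[C@@H]1CO` arises from compound 1 by hydroxy in place of amino on an aromatic carbon. For compound 2 this assay reports only a limit, > 200000 nM, not a number. The step that the limit leaves unreadable from compound 1 to compound 2 therefore cannot be read, because the limit of > 200000 nM in this assay, at which 1 of the 3 values shown sits, sits where the assay stops counting.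

Compound 4 `C=C1[C@H](n2cnc3c(O)nc(N)nc32)O[C@H](CO)[C@H]1O` has not yet been measured. It arises from compound 3 by hydroxy in place of amino on an aromatic carbon. Within the data shown here, this is the same kind of change as the one from compound 1 to compound 2, though the surroundings differ: in compound 4 the place is also meta to an amino group. Since the earlier step is unreadable, the expectation for compound 4 rests on two facts. The first is that compound 3 gives 8200 nM. The second is that the hydroxy-bearing compound 2 reached only a limit, which shows the hydroxy form was not stronger than compound 1. Compound 4 is expected to be weaker than compound 3, by an estimated step of a 4.9-fold higher number from compound 3 to compound 4 (0.69 log units; beyond the scatter). Compound 4 is thus estimated at 40000 nM, expected to fall between 8000 nM and 200000 nM.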

Compound 4, half-maximal inhibitory concentration: 8500 nM
For compound 4 the middle estimate is 4.7-fold (0.67 log units) above the measured one; low and high end bracket the measured number.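

Measured in this assay, hydroxy in place of amino on an aromatic carbon gives a 1.0-fold higher number from compound 3 to compound 4 (0.02 log units; within the scatter), so on this core the read-out does not separate the two groups, and the change can be made here without a visible cost in cell inhibition. The same change on the core of compound 1 cannot be read, because compound 2 stands at a limit of the assay and not at a number: the limit of > 200000 nM in this assay, at which 1 of the 4 values shown sits. The series therefore offers one readable step on one core, which shows that the change is tolerated on the core of compound 3 but does not show that it behaves the same way on the core of compound 1, so nothing here establishes that the result carries from one core to the other.

Going by these compounds, what remains open is whether this tolerance extends beyond hydroxy and amino, for example to a thiol, a chlorine or a methylamino group on the same aromatic carbon. On these data alone, it is also open whether the amino group that compound 3 and compound 4 both keep has any part in the result, since every readable comparison here retains it.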